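The source may report more compounds than this note shows. Statements on the series, on what has been measured and on what is new or still open speak of the compounds shown alone.

Compound 1 `Cc1cc(-c2cnn3c(NCC4CCOCC4)nc(NC4CCOCC4)nc23)ccc1C(=O)NC1CC1` is tested in a functional assay on HCT-116 cells (Homo sapiens) for antiproliferative activity (on this read-out lower numbers stand for stronger inhibition of growth and higher numbers for weaker inhibition of growth), and gives 280 nM. Two companions share the same read-out. Compound 3 `O=C(NC1CC1)c1ccc(-c2cnn3c(NCC4CCOCC4)nc(Oc4ccccc4)nc23)cc1` gives 200 nM in this assay, and the gap between compound 1 and compound 3 lies within the usual scatter of repeated measurements, so the two numbers cannot be told apart. Compound 2 `CN(c1nc(NCC2CCOCC2)n2ncc(-c3ccc(C(=O)NC4CC4)c(F)c3)c2n1)C1CCCCC1` has no result in this assay, with "not determined" (no result reported) recorded in place of a number, so compound 1 stands with one neighbour it matches and one about which nothing can be said.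

The step to compound 4 `Cc1cc(-c2cnn3c(NCC4CCOCC4)nc(Nc4ccccc4)nc23)ccc1C(=O)NC1CC1` is a single exchange: phenyl in place of oxan-4-yl on a nitrogen on an aromatic ring. Everything else in the molecule stays as it is in compound 1. Among the measured compounds shown here, no pair of measured compounds that differ in exactly this way is available, so the size of the step must be guessed rather than read off.

The expectation is a small move, if any, toward lower numbers in this assay, a step that stays within the scatter: a 1.4-fold lower number from compound 1 to compound 4 (0.15 log units; within the scatter). On that basis compound 4 is expected to give about 200 nM in this assay, with a plausible range from 80 nM to 500 nM.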

Compound 4, concentration for 50% growth inhibition: 690 nM
Estimate against measurement, compound 4: 3.5-fold (0.54 log units) below, and the stated range ends below it.
By their numbers in this assay, from the lowest: compounds 3 and 1 (each within the scatter of the next); then compound 4.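

In this assay, among the compounds shown here, the exchange on this nitrogen gives a 2.5-fold higher number from compound 1 to compound 4 (0.39 log units; beyond the scatter), a modest step beyond the scatter and the first clean single-change comparison in this set. It shows that this position is not indifferent to its group: two six-membered rings of equal heavy-atom count, oxan-4-yl and phenyl, do not give the same growth inhibition, and the anilino compound is the weaker of the pair. No measurement here bears on what lies behind the step, so the result stands as an observation without an explanation.

A single pair cannot separate the two differences between these groups, the loss of the ring oxygen and the arrival of an aromatic ring, and compound 2, which carries a cyclohexyl group on a methylated nitrogen, has no result to help. As far as these compounds go, a pyridine ring, which is aromatic but keeps a ring hetero atom, or a piperidine ring, which is non-aromatic and carries an amine, would be the kind of group needed to show which difference matters, and whether the step holds beyond this one pair remains open.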